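Methoxy to Bromo on the Sulfonyl Aryl Ring

A few compounds are considered here, and "the series" means these few. Any claim that something is new, unique, unknown or untested is made for them only; others in the source may bear on it.

Compound 1, `COc1cccc(S(=O)(=O)NC2=NCCN2C(=S)SN2CCn3c2nsc3=S)c1`: in a functional assay on KYSE-510 cells (Homo sapiens) for antiproliferative activity, read by crystal violet staining, with a stated time of 96 h (a higher number here means a weaker inhibitor of growth, a lower number a stronger inhibitor of growth), compound 1 gives >= 20000 nM, which is a limit of the assay.
Compound 2, `COc1ccc(S(=O)(=O)NC2=NCCN2C(=S)SN2CCn3c2nsc3=S)cc1`: in this assay compound 2 gives >= 20000 nM, which is also a limit of the assay.

Compound 2 therefore stands only at a limit, with no number of its own. Within the data shown here, the single step in this assay, a step that the two limits leave unreadable from compound 1 to compound 2, cannot be sized, since both of its ends are limits; the evidence reduces to the limit of >= 20000 nM in this assay, at which 2 of the 2 values shown sit. Compound 3, `O=S(=O)(NC1=NCCN1C(=S)SN1CCn2c1nsc2=S)c1ccc(Br)cc1`, differs from compound 2 by bromo in place of methoxy on an aromatic carbon. Among the measured compounds shown here, no measured step bears on this change, so the estimated step of a number no higher from compound 2 to compound 3 (the limit leaves the size open) is none beyond the scatter, and the outcome is expected to be a limit once more. For compound 3 the expected value is 20000 nM, in the range 6000 nM to 40000 nM.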

Compound 3, concentration for 50% growth inhibition: >= 20000 nM
Compound 3 ended at the assay's limit; the forecaster's own chance of this, stated with the estimate: 75%; the middle value lies on the limit itself.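

Compound 3 sits at a limit in this assay, as do compound 1 and compound 2, so no step among the three can be read: the limit of >= 20000 nM in this assay, at which 3 of the 3 values shown sit.

The compounds shown leave open whether any change on the sulfonyl aryl ring alters growth inhibition at all.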